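A few compounds are considered here, and "the series" means these few. Any claim that something is new, unique, unknown or untested is made for them only; others in the source may bear on it.

Measured so far in a functional assay on T47D cells (Homo sapiens) for antiproliferative activity, read by MTT assay, with a stated time of 48 h; on this read-out higher numbers stand for weaker inhibition and lower numbers for stronger inhibition:
- compound 1 `COc1ccc(/C=N/c2c(C#N)ncn2Cc2ccc(F)cc2)c(OC)c1OC`: > 25000 nM
- compound 2 `COc1cc(C2N=C(C(N)=O)c3ncn(-c4ccc(F)cc4)c3N2)cc(OC)c1OC`: 10700 nM
- compound 3 `COc1ccc(C2N=C(C(N)=O)c3ncn(-c4ccc(F)cc4)c3N2)cc1`: 5870 nM

Compound 1 has the entry > 25000 nM, which is a limit of the assay and not a number. Compound 3 at 5870 nM and compound 2 at 10700 nM lie within the scatter of each other, so compound 3 stands level with compound 2 on the two real numbers.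

Compound 4 `COc1ccc(C2N=C(C(N)=O)c3ncn(-c4ccc(F)cc4)c3N2)cc1OC` is next. It has methoxy in place of hydrogen on an aromatic carbon of compound 3, ortho to a methoxy group and meta to a large group: methoxy in place of hydrogen on an aromatic carbon.

Among the measured compounds shown here, no step between measured compounds is available. The expectation therefore rests on the closeness of compound 2 at 10700 nM and compound 3 at 5870 nM: no step beyond the scatter is expected in this assay, with only a slight lean towards a higher number. The estimated change is a 1.4-fold higher number from compound 3 to compound 4 (0.13 log units; within the scatter). The estimate for compound 4 is 8000 nM, with an expected range from 3500 nM to 18000 nM.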

Compound 4, half-maximal inhibitory concentration: 9960 nM
Compound 4: middle estimate off by 1.2-fold (0.10 log units), on the low side; the range from low to high includes it.
By their numbers in this assay, from the lowest: compounds 3, 4 and 2 (each within the scatter of the next). At a limit, above all of these: compound 1.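

In this assay, methoxy in place of hydrogen on an aromatic carbon, ortho to a methoxy group, gives a 1.7-fold higher number from compound 3 to compound 4 (0.23 log units; within the scatter), so this position takes the added methoxy without a step beyond the scatter. Among the compounds shown here, the reverse kind of change, hydrogen in place of methoxy on an aromatic carbon, gives a 1.1-fold lower number from compound 2 to compound 4 (0.03 log units; within the scatter), so compound 2, compound 3 and compound 4 now form a set linked by single changes, with no step in it beyond the scatter. Compound 1 stands at a limit of the assay and not at a number, and it adds no step to this set: the limit of > 25000 nM in this assay, at which 1 of the 4 values shown sits.

As far as these compounds go, whether any group at this position can move the number beyond the scatter stays open. A hydroxyl group, an amine or a carboxylic acid in place of methoxy, or a longer chain on the oxygen, would test this.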